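Fluoro in Place of Chloro at Two Different Places

A few compounds are considered here, and "the series" means these few. Any claim that something is new, unique, unknown or untested is made for them only; others in the source may bear on it.

Of the compounds shown here, three have been tested in an ADME assay on HEK-293T cells (Homo sapiens) for inhibition, read by CCK-8 assay, with a stated time of 48 h, tested at 20 uM; on this read-out higher numbers stand for more inhibition of growth at the one concentration tested and lower numbers for less inhibition of growth. Compound 1 `N#C/C(=C\c1ccccc1OS(=O)(=O)c1ccc([N+](=O)[O-])cc1)C(=O)Nc1nnc(Cc2ccc(F)cc2)s1` gives 8%, compound 2 `N#C/C(=C\c1ccccc1OS(=O)(=O)c1ccc([N+](=O)[O-])cc1)C(=O)Nc1nnc(Cc2ccc(Cl)cc2)s1` gives 19%, and compound 3 `Cc1ccc(Cc2nnc(NC(=O)/C(C#N)=C/c3ccccc3OS(=O)(=O)c3ccc(Cl)cc3)s2)cc1` gives 8%, level with compound 1 at the digits shown. Between compound 2 and compound 1 the change is fluoro in place of chloro on an aromatic carbon, and the step was a number 11 percentage points lower from compound 2 to compound 1 (beyond the scatter). The cores of compound 2 and compound 3 differ in more than one place; that difference is not broken down here. Compound 4 `Cc1ccc(Cc2nnc(NC(=O)/C(C#N)=C/c3ccccc3OS(=O)(=O)c3ccc(F)cc3)s2)cc1` is not yet measured; it differs from compound 3 by fluoro in place of chloro on an aromatic carbon. This is the same kind of change as from compound 2 to compound 1, at a place described in the same words, but cut one bond further out it reads (4-chlorophenyl)sulfonyl to (4-fluorophenyl)sulfonyl rather than 4-chlorobenzyl to 4-fluorobenzyl. A smaller step than a number 11 percentage points lower from compound 2 to compound 1 (beyond the scatter) is expected in this assay, namely a number 3 percentage points lower from compound 3 to compound 4 (within the scatter), as compound 3 already starts low at 8%. Compound 4 is expected to give 5%, between -5% and 15%.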

Compound 4, percent growth inhibition at one concentration: 11%
Estimate against measurement, compound 4: 6 percentage points below, and the stated range covers the measured number.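

In this assay, fluoro in place of chloro on the sulfonyl side gives a number 3 percentage points higher from compound 3 to compound 4 (within the scatter), so this pair shows no clear change. Set beside the earlier step, the new one cannot be told apart from it: the same change on two cores in this assay, a number 11 percentage points lower (beyond the scatter) from compound 2 to compound 1 and a number 3 percentage points higher (within the scatter) from compound 3 to compound 4, 14 percentage points apart, within the scatter of two such steps This does not show that the change carries from one core to another with a fixed effect, nor that it fails to carry, as there is one pair per core and the swaps sit at differently named groups, 4-chlorobenzyl and (4-chlorophenyl)sulfonyl.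

Still open, from the compounds shown here alone, is how a bromo or a methoxy group at this place, para to a large group, would read in this assay. Also open, going by these compounds, is how the change would read with both places on a single core.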